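Working notes: inverting the single stereocentre of compound 3

The source may report more compounds than this note shows. Statements on the series, on what has been measured and on what is new or still open speak of the compounds shown alone.

Values in a functional assay on A549 cells (Homo sapiens) for cytotoxicity, read by MTT assay, with a stated time of 72 h (on this read-out lower numbers stand for stronger inhibition and higher numbers for weaker inhibition), are these:
- compound 1 (`O=C1c2c[n+]([O-])c3ccccc3c2C(=O)c2c1c1ccccc1n2Cc1cn([C@H]2O[C@H](CO)[C@@H](O)[C@H]2O)nn1`) gives 2680 nM
- compound 2 (`O=C1c2c[n+]([O-])c3ccccc3c2C(=O)c2c1c1ccccc1n2Cc1cn(CC(O)CO)nn1`) gives 880 nM
- compound 3 (`CC1(C)OC[C@H](Cn2cc(Cn3c4c(c5ccccc53)C(=O)c3c[n+]([O-])c5ccccc5c3C4=O)nn2)O1`) gives 340 nM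

Compound 3 has the lowest number of the three in this assay, with compound 2 nearest (a 2.6-fold lower number from compound 2 to compound 3 (0.41 log units; beyond the scatter)) and compound 1 furthest (a 7.9-fold lower number from compound 1 to compound 3 (0.90 log units; beyond the scatter)). The next structure is compound 4 (`CC1(C)OC[C@@H](Cn2cc(Cn3c4c(c5ccccc53)C(=O)c3c[n+]([O-])c5ccccc5c3C4=O)nn2)O1`), and the change is the two compounds have the same atoms and bonds and differ only in configuration as drawn: 1 of 1 stereo elements differ; a stereocentre at a saturated ring carbon is drawn S in compound 3 and R in compound 4. Among the measured compounds shown here, no measured pair isolates a change of configuration. The nearest guide is the set of side-chain replacements, and these changed the group itself, yet each step stayed modest (a 3.0-fold lower number from compound 1 to compound 2 (0.48 log units; beyond the scatter) and the two above). A change that leaves every atom and bond in place is therefore expected to give a step no larger than these, quite possibly none beyond the scatter. Any shift is expected to lean slightly upward, since compound 3 sits at the low end of the series. The estimated step is small (a 1.2-fold higher number from compound 3 to compound 4 (0.09 log units; within the scatter)). Compound 4 is estimated at 420 nM (expected range 170 nM to 1000 nM).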

Compound 4, half-maximal inhibitory concentration: 4700 nM
The estimate for compound 4 lay 11-fold (1.05 log units) below the measured number; measured number above the stated range.
By their numbers in this assay, from the lowest: compound 3; then compound 2; then compounds 1 and 4 (each within the scatter of the next).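

Read in this assay the stereocentre at the saturated ring carbon of the 2,2-dimethyl-1,3-dioxolan-4-yl group carries a large step (a 14-fold higher number from compound 3 to compound 4 (1.14 log units; beyond the scatter)), where every side-chain replacement so far gave a modest one, and that step can be assigned to this centre alone because of one fact: the fact that compounds 3 and 4 differ only in the configuration as drawn. The 2,2-dimethyl-1,3-dioxolan-4-yl group therefore does not give a low number on its own: compound 3 lies below compound 2, yet the R form moves the other way (a 5.3-fold higher number from compound 2 to compound 4 (0.73 log units; beyond the scatter)). Against compound 1 the R form shows no separation (a 1.8-fold higher number from compound 1 to compound 4 (0.24 log units; within the scatter)).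

From the compounds shown here alone, compound 2 is drawn without a stated configuration, so whether its 1,2-dihydroxyethyl carbon is equally sensitive stays open. Also open, going by these compounds, is whether the preference for S survives with an amine or a carboxylic acid on that chain in place of the dioxolane.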